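This account rests on a few compounds, and the source may have more. Where it says the series, first, only, none or still open, it means among the compounds named here.

Measured compounds in a functional assay on cells (Platelet, Homo sapiens) for inhibition; on this read-out lower numbers stand for stronger inhibition and higher numbers for weaker inhibition:
Compound 1 `CCOC(=O)c1ccc(-c2nn(C)c3ccccc23)cc1` gives > 10000 nM, which is a limit of the assay, not a number.
Compound 2 `CCOC(=O)c1ccc(-c2nn(Cc3ccccc3Cl)c3ccccc23)cc1` gives > 10000 nM, also a limit.
Compound 3 `CCOC(=O)c1ccc(-c2nn(Cc3ccc(Cl)cc3)c3ccccc23)cc1` gives > 10000 nM, again a limit.

Compound 3 thus stands at the limit of > 10000 nM in this assay, at which 3 of the 3 values shown sit, with no number of its own. Compound 4 `CCOC(=O)c1ccc(-c2nn(Cc3ccccc3OC)c3ccccc23)cc1` differs from it by 2-methoxyphenyl in place of 4-chlorophenyl on a saturated chain carbon bound to an aromatic nitrogen. The measured steps at the same place, a step that the two limits leave unreadable from compound 1 to compound 3, a step that the two limits leave unreadable from compound 1 to compound 2 and a step that the two limits leave unreadable from compound 2 to compound 3, are all unreadable because the limit of > 10000 nM in this assay, at which 3 of the 3 values shown sit, holds at both ends of each. Among the measured compounds shown here, no read step therefore bears on the change, and no direction can be expected for this assay beyond the scatter. The estimated step that the limit leaves unreadable from compound 3 to compound 4 is expected to be about none. Compound 4 is expected to give 30000 nM, within 8000 nM to 200000 nM, most likely again reported only as a limit.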

Compound 4, half-maximal inhibitory concentration: > 10000 nM
Compound 4: only a limit was reported (the forecaster's own chance of this, stated with the estimate: 85%); the middle value does not contradict the limit.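

In this assay, among the compounds shown here, compound 4 gives > 10000 nM, a limit and not a number, so no step linking compounds 1, 2, 3 and 4 can be read: the limit of > 10000 nM in this assay, at which 4 of the 4 values shown sit. Going by these compounds, whether any group on a saturated chain carbon bound to an aromatic nitrogen gives measurable inhibition stays open.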